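Boronate Chalcone Series: Aryl Swap at the Carbonyl

The source may report more compounds than this note shows. Statements on the series, on what has been measured and on what is new or still open speak of the compounds shown alone.

Three compounds of the series have numbers in a functional assay on HCT-116 cells (Homo sapiens) for cytotoxicity, read by MTT assay, with a stated time of 48 h; a lower number here means a stronger inhibitor, a higher number a weaker inhibitor. Compound 1 `O=C(/C=C/c1ccc2c(c1)B(O)OC2)c1cccnc1` gives 20500 nM, the second highest of the three. Compound 2 `Cc1ccc(C(=O)/C=C/c2ccc3c(c2)B(O)OC3)cc1C` gives 6100 nM, while compound 3 `O=C(/C=C/c1ccc2c(c1)B(O)OC2)c1ccccc1O` gives 77900 nM. Going by the values given here, the only single-point step measured so far is a 3.8-fold higher number from compound 1 to compound 3 (0.58 log units; beyond the scatter), a modest change beyond the scatter. Compound 4 `O=C(/C=C/c1ccc2c(c1)B(O)OC2)c1cccc(O)c1` differs from compound 1 by 3-hydroxyphenyl in place of pyridin-3-yl on a carbonyl carbon. The step from compound 1 to compound 3 bears on this most closely, as both exchange the pyridin-3-yl for a hydroxyphenyl; compound 2 shows that a carbon-only ring on this carbon can also give a lower number, so the direction is not settled. For compound 4 a small rise is expected, a 1.2-fold higher number from compound 1 to compound 4 (0.09 log units; within the scatter). Compound 4 is therefore estimated at 25000 nM, between 8000 nM and 80000 nM.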

Compound 4, half-maximal inhibitory concentration: 6500 nM
Beside the measured number, compound 4's estimate is 3.8-fold (0.59 log units) above it, and the stated range ends above it.
By their numbers in this assay, from the lowest: compounds 2 and 4 (each within the scatter of the next); then compound 1; then compound 3.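

At this carbonyl carbon, a hydroxyphenyl does not push this assay in one direction: 3-hydroxyphenyl gives a 3.2-fold lower number from compound 1 to compound 4 (0.50 log units; beyond the scatter), whereas 2-hydroxyphenyl raised the number. The exchange between the two hydroxyphenyl groups is the largest step here, with a 12-fold lower number from compound 3 to compound 4 (1.08 log units; beyond the scatter), so the hydroxyl's ring position separates these two compounds more than its presence does. Nothing at hand gives a reason for this difference. As far as these compounds go, whether a 3-methoxyphenyl or 3-aminophenyl on this carbon would hold the number of compound 4 remains open. From the compounds shown here alone, whether this order holds outside this assay also remains open.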